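The source may report more compounds than this note shows. Statements on the series, on what has been measured and on what is new or still open speak of the compounds shown alone.

Measured compounds in an assay on HEK293 cells for agonist activity at transient receptor potential cation channel subfamily M member 8 (Homo sapiens), read by fluorescence and calcium flux, with a stated time of 15 min; a lower number here means that less compound is needed, a higher number that more compound is needed for the effect:
- compound 1 `CCN(Cc1cccs1)C(=O)c1cc2cc(C)ccc2[nH]1`: 2010 nM
- compound 2 `CCN(Cc1cccs1)C(=O)COc1ccccc1`: 1400 nM
- compound 3 `Cc1ccc(OCC(=O)N(Cc2cccs2)c2nccs2)cc1`: 2240 nM

Compound 3 has the highest number of the three, but its values against compound 1 and against compound 2 lie within the scatter, so the three compounds show no separation in this assay on these data. Going by the values given here, no pair differing in a single place has been measured, so no step size is known for the series.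

Compound 4 `Cc1ccc(OCC(=O)N(Cc2cccs2)c2cnn(C)c2)cc1` differs from compound 3 in one place, (1-methyl-1H-pyrazol-4-yl in place of 1,3-thiazol-2-yl on an amide-type nitrogen). Among the compounds with values here, with no measured step between single-change pairs to lean on, the expectation for this change in this assay is a step of no more than the scatter, in either direction, with the estimate placed close to the number of compound 3.

Compound 4 is therefore estimated at 2500 nM, with a range of 1000 nM to 6500 nM. This estimate means a step of a 1.1-fold higher number from compound 3 to compound 4 (0.05 log units; within the scatter), expected to stay within the usual scatter.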

Compound 4, half-maximal effective concentration: 63000 nM
Beside the measured number, compound 4's estimate is 25-fold (1.40 log units) below it; the measured number lies above the stated range.
By their numbers in this assay, from the lowest: compounds 2, 1 and 3 (each within the scatter of the next); then compound 4.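

Within this assay, the group on the amide-type nitrogen is the first place in the series where a single change has a known size: 1-methyl-1H-pyrazol-4-yl in place of 1,3-thiazol-2-yl gives a 28-fold higher number from compound 3 to compound 4 (1.45 log units; beyond the scatter). This place therefore does not tolerate every five-membered aromatic ring. The two groups are alike in ring size, hetero atom count, hydrogen-bond donor and acceptor counts and net charge, so these counts do not settle the outcome here, and no measurement at hand accounts for the step.

Open, on these data alone, is whether the step follows the methyl, the pyrazole ring or its point of attachment, which 1H-pyrazol-4-yl without the methyl would help to separate. Also open, as far as these compounds go, is how this place responds to a phenyl ring, an amine or a carboxylic acid.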